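Hydroxymethyl in place of formyl: a working note

The source may report more compounds than this note shows. Statements on the series, on what has been measured and on what is new or still open speak of the compounds shown alone.

Measured in an ADME assay on T29 cells (Homo sapiens) for cytotoxicity, read by sulforhodamine B assay, with a stated time of 3 days; a lower number here means a stronger inhibitor, a higher number a weaker inhibitor:
compound 1 `O=Cc1cn(Cc2cccc(C(F)(F)F)c2)c2ccccc12`: > 31600 nM (a limit)
compound 2 `O=Cc1cn(Cc2ccc(Cl)cc2)c2ccc(Cl)cc12`: > 31600 nM (a limit)
compound 3 `OCc1cn(Cc2ccc(Br)cc2)c2ccccc12`: > 31600 nM (a limit)

Compound 1 has no numerical value, only a limit. All measured compounds sit at the limit of > 31600 nM in this assay, at which 3 of the 3 values shown sit, and no ranking can be drawn among them.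

The next compound is compound 4 `OCc1cn(Cc2cccc(C(F)(F)F)c2)c2ccccc12`, which has hydroxymethyl in place of formyl on an aromatic carbon of the core of compound 1 (hydroxymethyl in place of formyl on an aromatic carbon). Going by the values given here, no measured pair isolates this change, so the data give no direct size for it. Compound 3 also carries hydroxymethyl and gives > 31600 nM, which is again a limit. On that basis, no step beyond the scatter is expected in this assay, and compound 4 is expected to be reported as a limit as well. The estimated step is a step that the limit leaves unreadable from compound 1 to compound 4. If a number is obtained, compound 4 is expected to read about 35000 nM, within an estimated range of 12000 nM to 80000 nM.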

Compound 4, half-maximal inhibitory concentration: > 31600 nM
Compound 4: a limit, no number; the forecaster's own chance of this, stated with the estimate: 80%; the middle value is on the limit's open side.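

No step can be read from compound 1 to compound 4 because both compounds stay at a limit, not a number: the limit of > 31600 nM in this assay, at which 4 of the 4 values shown sit. The compounds shown leave open whether hydroxymethyl in place of formyl on an aromatic carbon shifts the read-out at all, and how these four compounds rank.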